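The compounds below may be only part of what the source reports. "The series", "measured", "known", "first", "only" and "open" are said of these compounds alone.

Measured in a physicochemical assay for solubility, in phosphate buffer, measured as kinetic solubility, at pH 7.2; on this read-out higher numbers stand for higher solubility and lower numbers for lower solubility:

Compound 1 `COC(=O)N[C@H](C(=O)N1CCC[C@H]1C(=O)Nc1ccc([C@@H]2CC[C@@H](c3ccc(NC(=O)[C@@H]4CCCN4C(=O)[C@@H](NC(=O)OC)[C@@H](C)OC)cc3)N2c2ccc(F)cc2)cc1)[C@@H](C)OC` gives 9600 nM
Compound 2 `COC(=O)N[C@H](C(=O)N1CCC[C@H]1C(=O)Nc1ccc([C@@H]2CC[C@@H](c3ccc(NC(=O)[C@@H]4CCCN4C(=O)[C@@H](NC(=O)OC)C(C)C)cc3)N2c2ccc(C(F)(F)F)cc2)cc1)C(C)C` gives 3400 nM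
Compound 3 `COC(=O)N[C@H](C(=O)N1CCC[C@H]1C(=O)Nc1ccc([C@@H]2CC[C@@H](c3ccc(NC(=O)[C@@H]4CCCN4C(=O)[C@@H](NC(=O)OC)[C@H]4CCOC4)cc3)N2c2ccc(F)cc2)cc1)[C@H]1CCOC1` gives 9700 nM

Among these three, compound 3 has the highest number in this assay, yet its gap to compound 1 is nil and lies within the scatter, so the two cannot be ranked against each other; only compound 2 sits clearly lower, beyond the scatter. Compound 4 `COC(=O)N[C@H](C(=O)N1CCC[C@H]1C(=O)Nc1ccc([C@H]2CC[C@H](c3ccc(NC(=O)[C@@H]4CCCN4C(=O)[C@@H](NC(=O)OC)[C@H]4CCOC4)cc3)N2c2ccc(F)cc2)cc1)[C@H]1CCOC1` has not yet been measured. Relative to compound 3 the change is the two compounds have the same atoms and bonds and differ only in configuration as drawn: 2 of 8 stereo elements differ; a stereocentre at a saturated ring carbon is drawn S in compound 3 and R in compound 4; a stereocentre at a saturated ring carbon is drawn S in compound 3 and R in compound 4. Among the compounds with values here, no measured pair here differs only in configuration, so there is no direct precedent. The atoms and bonds are unchanged, and a step of a 1.1-fold lower number from compound 3 to compound 4 (0.03 log units; within the scatter) is expected, not beyond the scatter in either direction. Compound 4 is therefore estimated at 9000 nM, with a range from 4000 nM to 20000 nM.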

Compound 4, solubility: 8500 nM
The estimate for compound 4 lay 1.1-fold (0.02 log units) above the measured number, within the range that was stated.
By their numbers in this assay, from the lowest: compound 2; then compounds 4, 1 and 3 (each within the scatter of the next).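

Within the data shown here, the only comparison here that isolates a single feature is a pair with nothing else altered: the fact that compounds 3 and 4 differ only in the configuration as drawn. In this assay this pair shows a 1.1-fold lower number from compound 3 to compound 4 (0.06 log units; within the scatter). Redrawing the two saturated ring carbons from S to R therefore does not separate the two compounds on this read-out, at least with these side groups.

Among these compounds, it remains open what redrawing only one of the two ring carbons would give. Going by these compounds, it is also open whether the same pair of configurations would stay as close in compounds carrying an amine or a carboxylic acid.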